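Methoxy to methyl on the benzoyl ring of compound 1

A few compounds are considered here, and "the series" means these few. Any claim that something is new, unique, unknown or untested is made for them only; others in the source may bear on it.

Compound 1 `COc1cc2ncnc(NNC(=S)NC(=O)c3ccccc3OC)c2cc1OC` gives 8410 nM in this study.
Compound 2 `O=C(NC(=S)NNc1ncnc2ccccc12)c1cccc(Cl)c1` gives 2920 nM in the same study.

Both compounds were tested in a functional assay on CNE-2 cells (Homo sapiens) for cytotoxicity, read by MTT assay, with a stated time of 72 h; on this read-out lower numbers stand for stronger inhibition and higher numbers for weaker inhibition. Of the two numbers measured, compound 1 has the higher one: compound 1 gives 8410 nM, while compound 2 gives 2920 nM, and the gap between them lies beyond the usual scatter of the method, so compound 1 is the weaker of the two. Going by the values given here, compounds 1 and 2 differ in more than one place, so no single step can be read between them; their two values show only that compound 2 inhibits growth of the cells more strongly.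

Compound 3 `COc1cc2ncnc(NNC(=S)NC(=O)c3ccccc3C)c2cc1OC` has not yet been measured. It differs from compound 1 in one place: methyl in place of methoxy on an aromatic carbon. Nothing measured here speaks to the size of this particular step, so the expectation rests on the change being a small one at the edge of the molecule. The step from compound 1 to compound 3 is expected to be a 1.2-fold lower number from compound 1 to compound 3 (0.08 log units; within the scatter), a shift not beyond the scatter. On that basis compound 3 is estimated to give 7000 nM, with a plausible range from 3000 nM to 18000 nM.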

Compound 3, half-maximal inhibitory concentration: 10500 nM
For compound 3 the middle estimate is 1.5-fold (0.18 log units) below the measured one; the measured number falls inside the stated range.
By their numbers in this assay, from the lowest: compound 2; then compounds 1 and 3 (each within the scatter of the next).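

In this assay, the change from methoxy to methyl on this aromatic carbon, ortho to a large group, reads as a 1.2-fold higher number from compound 1 to compound 3 (0.10 log units; within the scatter), so the 2-methoxyphenyl and 2-methylphenyl compounds cannot be told apart on this read-out. Going by these compounds alone, this is the only step here that can be read in one place, as compound 1 and compound 2 differ in more than one place. It shows that at this position, methyl can stand in for methoxy, with one heavy atom and one hydrogen-bond acceptor fewer, without a shift beyond the scatter. Nothing else given here bears on what lies behind this result.

What the compounds shown leave open is whether this position stays as indifferent to a group of another kind, such as an amine or a carboxylic acid, as it is to methoxy and methyl. Within the data shown here, they also leave open whether the same change would read alike on the core of compound 2, which has no counterpart of this step among the values shown.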